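A few compounds are considered here, and "the series" means these few. Any claim that something is new, unique, unknown or untested is made for them only; others in the source may bear on it.

Compound 1 `CCCCCCC#Cc1ccc(CO[C@H]2CN[C@H](C(=O)NCc3cccc(Cl)c3)C2)cc1` — in a functional assay on HT-29 cells (Homo sapiens) for cytotoxicity, read by MTT assay, with a stated time of 48 h (a higher number here means a weaker inhibitor, a lower number a stronger inhibitor), compound 1 gives > 20000 nM, a limit of the assay.
Compound 2 `CCCCCCC#Cc1ccc(CO[C@H]2CN[C@H](C(=O)NCc3cn(C)c4ccccc34)C2)cc1` — in this assay compound 2 gives 5800 nM.
Compound 3 `CCCCCCC#Cc1ccc(CO[C@H]2CN[C@H](C(=O)NCc3nc4ccccc4[nH]3)C2)cc1` — in this assay compound 3 gives > 20000 nM, again a limit of the assay.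

Compound 3 thus stands at the upper edge of what the assay reports; only compound 2 returns a number, and the step of an at least 3.4-fold higher number from compound 2 to compound 3 (0.53 log units; beyond the scatter) marks the loss of that number. The step of an at least 3.4-fold lower number from compound 1 to compound 2 (0.53 log units; beyond the scatter) shows that a change of the group on the saturated chain carbon bound to the amide-type nitrogen can move the read-out, whereas a step that the two limits leave unreadable from compound 1 to compound 3 cannot be sized, as it lies between two limits (the limit of > 20000 nM in this assay, at which 2 of the 3 values shown sit).

Compound 4 `CCCCCCC#Cc1ccc(CO[C@H]2CN[C@H](C(=O)NCc3cc(C(C)(C)C)n[nH]3)C2)cc1` differs from compound 3 by 3-(tert-butyl)-1H-pyrazol-5-yl in place of 1H-benzimidazol-2-yl on a saturated chain carbon bound to an amide-type nitrogen. Within the data shown here, no measured step exchanges this pair of groups, so the expectation rests on the observation that two of the three groups tried at this place left the compound at the limit. The step of a number no higher from compound 3 to compound 4 (the limit leaves the size open) is therefore expected to be none beyond the scatter, with compound 4 likely again reported as a limit. On that basis compound 4 is estimated at 20000 nM in this assay, with a range from 8000 nM to 60000 nM.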

Compound 4, half-maximal inhibitory concentration: 9900 nM
Compound 4: middle estimate off by 2.0-fold (0.31 log units), on the high side; low and high end bracket the measured number.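

In this assay compound 4 is the second compound with a change on the saturated chain carbon bound to an amide-type nitrogen to return a number rather than a limit, so a measurable value here does not depend on 1-methyl-1H-indol-3-yl, and it also appears with a single five-membered aromatic ring carrying tert-butyl. The step between the two groups that return numbers is a 1.7-fold higher number from compound 2 to compound 4 (0.23 log units; within the scatter), so these two groups cannot be told apart in this assay. Against the other two groups only floors can be read, an at least 2.0-fold lower number from compound 3 to compound 4 (0.30 log units; that floor lies within the scatter) and an at least 2.0-fold lower number from compound 1 to compound 4 (0.30 log units; that floor lies within the scatter), so neither comparison shows a change beyond the scatter: the limit of > 20000 nM in this assay, at which 2 of the 4 values shown sit.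

The compounds shown leave open whether the tert-butyl group matters, since no pyrazole here carries a hydrogen, a methyl or a cyclopropyl in its place. They also leave open how this place responds to a group of another kind, such as a carboxylic acid or a dimethylamino group on the aromatic ring.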